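The source may report more compounds than this note shows. Statements on the series, on what has been measured and on what is new or still open speak of the compounds shown alone.

Measured so far in an ADME assay on HEK293 cells (Homo sapiens) for cytotoxicity, with a stated time of 72 h; on this read-out higher numbers stand for an effect only at larger amounts of compound and lower numbers for an effect already at smaller amounts:
compound 1 `Cc1cc(NC(=O)Nc2cccc(Cl)c2)c2ccccc2n1` — 21000 nM
compound 2 `Cc1cc(NC(=O)Nc2ccc(F)cc2)c2ccccc2n1` — a limit of this assay only, > 25000 nM

Compound 2 stands at the limit of this assay and gives no number. Among the measured compounds shown here, the only measured step, an at least 1.1-fold higher number from compound 1 to compound 2 (0.07 log units; that floor lies within the scatter), runs from a number up to that limit, and the limit of > 25000 nM in this assay, at which 1 of the 2 values shown sits, is all that bounds its size. Compound 3 `Cc1cc(NC(=O)Nc2ccc(OC(F)(F)F)cc2)c2ccccc2n1` differs from compound 2 by trifluoromethoxy in place of fluoro on an aromatic carbon. For the measured compounds named here, no measured step exchanges a fluoro for a trifluoromethoxy group, so the one measured step bears on compound 3 only in showing that both measured compounds sit at or near the top of the range read in this assay. For compound 3 the step of an at least 1.1-fold lower number from compound 2 to compound 3 (0.05 log units; that floor lies within the scatter) is therefore expected to stay within the scatter, with no direction assigned. The estimate for compound 3 in this assay is 22000 nM, with a range from 9000 nM to 45000 nM, and a fair chance that only a limit is again reported.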

Compound 3, half-maximal effective concentration: 14000 nM
Compound 3: middle estimate off by 1.6-fold (0.20 log units), on the high side, and the stated range covers the measured number.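

In this assay, among the compounds shown here, trifluoromethoxy in place of fluoro, para to a large group, gives an at least 1.7-fold lower number from compound 2 to compound 3 (0.25 log units; that floor lies within the scatter), the first step read at this position. Compound 2 has only a limit of this assay, > 25000 nM. The step is therefore a floor, and its true size stays unknown because one end of it is not a number: the limit of > 25000 nM in this assay, at which 1 of the 3 values shown sits.

For the compounds shown here, whether the exchange of fluoro for trifluoromethoxy moves the read-out beyond the scatter remains open, as only one end of the step is a number. Also open, as far as these compounds go, is how an amine or a carboxylic acid at the same place on the aromatic ring would read in this assay, and whether any group there would bring the number clearly down.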